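The compounds below may be only part of what the source reports. "The series", "measured", "known", "first", "only" and "open" are said of these compounds alone.

In a functional assay on RS4-11 cells (Homo sapiens) for inhibition, read by CCK-8 assay, with a stated time of 48 h, tested at 20 uM (a lower number here means less inhibition of growth, a higher number more inhibition of growth at the concentration tested), compound 1 `Cc1ccc(S(=O)(=O)Oc2ccccc2/C=C(\C#N)C(=O)Nc2nnc(C)s2)cc1` gives 33% of growth inhibition, while compound 2 `N#C/C(=C\c1ccccc1OS(=O)(=O)c1ccccc1[N+](=O)[O-])C(=O)Nc1nnc(Cc2ccccc2)s1` gives 71% and compound 3 `N#C/C(=C\c1ccccc1OS(=O)(=O)c1ccc(Cl)cc1)C(=O)Nc1nnc(-c2cccc(F)c2)s1` gives 71% in the same test. Compound 3 therefore stands level with compound 2, the two together holding the highest of the three numbers, and compound 1 lies lower by a gap beyond the scatter. Compound 4 `Cc1ccc(Cc2nnc(NC(=O)/C(C#N)=C/c3ccccc3OS(=O)(=O)c3ccc(Cl)cc3)s2)cc1` has not yet been measured. It departs from compound 3 in one place, on an aromatic carbon of a five-membered aromatic ring with 2 nitrogen and 1 sulfur, where 4-methylbenzyl stands in place of 3-fluorophenyl 4-methylbenzyl in place of 3-fluorophenyl on an aromatic carbon in the structure. For the measured compounds named here, no measured pair differs in one place only, so the size of this step cannot be read directly. The expectation rests on compound 3 at 71% and compound 2 at 71% standing level, and no step beyond the scatter is expected. The estimated change is a number 3 percentage points lower from compound 3 to compound 4 (within the scatter) in this comparison. In this assay the expected value for compound 4 is 68% with 50% to 85% as the estimated range.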

Compound 4, percent growth inhibition at one concentration: 72%
Beside the measured number, compound 4's estimate is 4 percentage points below it; low and high end bracket the measured number.
By their numbers in this assay, from the lowest: compound 1; then compounds 2, 3 and 4 (each within the scatter of the next).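

In this assay, for the compounds shown here, placing 4-methylbenzyl in place of 3-fluorophenyl on this aromatic carbon gives a number 1 percentage points higher from compound 3 to compound 4 (within the scatter), the first step at this position that can be read with the rest of the molecule held fixed. The earlier compounds shown here differed from one another in more than one place, so they could not show this. The new pair shows that, in this setting, a ring attached through a carbon link and a ring attached directly to the aromatic carbon give growth inhibition within the scatter of each other at the concentration tested. Nothing shown here gives a reason for this result.

On these data alone, whether an amine, a carboxylic acid or a longer alkyl chain on this carbon would give the same growth inhibition remains open. So does whether this step would hold if the sulfonate part of the molecule were different.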